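From thiophen-3-yl to pyridin-3-yl on a shared core

The compounds below may be only part of what the source reports. "The series", "measured", "known", "first", "only" and "open" are said of these compounds alone.

Measured in a functional assay on HeLa cells (Homo sapiens) for cytotoxicity, read by ELISA, with a stated time of 2 days; on this read-out higher numbers stand for weaker inhibition and lower numbers for stronger inhibition
Compound 1 `Oc1cccc(-c2cc(-c3ccccc3)cc(-c3ccncc3)n2)c1` gives 28100 nM
Compound 2 `Oc1cccc(-c2cc(-c3ccccc3)nc(-c3ccsc3)c2)c1` gives 14900 nM

Compound 2 and compound 1 lie within the usual scatter of each other, so these two numbers do not separate them. Compound 3 `Oc1cccc(-c2cc(-c3ccccc3)nc(-c3cccnc3)c2)c1` carries pyridin-3-yl in place of thiophen-3-yl on an aromatic carbon next to the ring nitrogen. Among the compounds with values here, no measured pair shows this swap on its own, so no step beyond the scatter is expected in this assay and the estimated step stays small (a 1.3-fold higher number from compound 2 to compound 3 (0.13 log units; within the scatter)). For compound 3 the estimated value is 20000 nM (expected range 8000 nM to 50000 nM).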

Compound 3, half-maximal inhibitory concentration: 17500 nM
Compound 3: middle estimate off by 1.1-fold (0.06 log units), on the high side, and the stated range covers the measured number.
By their numbers in this assay, from the lowest: compounds 2, 3 and 1 (each within the scatter of the next).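

In this assay, pyridin-3-yl in place of thiophen-3-yl on this aromatic carbon gives a 1.2-fold higher number from compound 2 to compound 3 (0.07 log units; within the scatter), so a six-membered and a five-membered aromatic ring cannot be told apart here. At this position, the extra ring atom brings no step beyond the scatter. No measurement shown gives a reason for this result. As far as these compounds go, both groups are aromatic rings, so it remains open whether an amine or a carboxylic acid on this carbon would give a clearly different number. The compounds also leave open whether the same swap would read alike on another cell line.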